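Moving the methyl around the anilino ring of compound 2

The source may hold more compounds than are shown below. What is called first, only, known or untested is meant among the compounds shown, and "the series" means these compounds.

Two compounds of this series carry measurements. Compound 1 `O=C(CSc1nc(Nc2ccccc2)c2ccccc2n1)Nc1ccc(F)c(Cl)c1` gives 21600 nM in a functional assay on MDA-MB-231 cells (Homo sapiens) for inhibition, read by MTT assay, with a stated time of 72 h; a higher number here means a weaker inhibitor, a lower number a stronger inhibitor. Compound 2 `C=CC(=O)Nc1cccc(NC(=O)CSc2nc(Nc3ccccc3C)c3ccccc3n2)c1` gives 20400 nM in this assay. Compound 2 has the lower of the two numbers, but the gap to compound 1 is within the scatter of such measurements, so the two cannot be told apart. The new compound 3 `C=CC(=O)Nc1cccc(NC(=O)CSc2nc(Nc3cccc(C)c3)c3ccccc3n2)c1` differs from compound 2 in one respect: 3-methylphenyl in place of 2-methylphenyl on a nitrogen on an aromatic ring. Going by the values given here, nothing else in the molecule changes, and no pair of measured compounds shows what such a shift of a methyl around that ring does in this assay. Among the compounds with values here, with both measured numbers so close, and no comparable step on record, the expectation for compound 3 rests on compound 2 alone, and the step of a 1.1-fold lower number from compound 2 to compound 3 (0.03 log units; within the scatter) is expected to stay within the scatter, in no clear direction. Compound 3 is therefore estimated at 19000 nM, with a range from 8000 nM to 45000 nM.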

Compound 3, half-maximal inhibitory concentration: 16800 nM
For compound 3 the middle estimate is 1.1-fold (0.05 log units) above the measured one; measured number inside the range.
By their numbers in this assay, from the lowest: compounds 3, 2 and 1 (each within the scatter of the next).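

The series now has its first step between measured compounds that differ in one place: in this assay, 3-methylphenyl in place of 2-methylphenyl on the nitrogen gives a 1.2-fold lower number from compound 2 to compound 3 (0.08 log units; within the scatter) and thus leaves the two compounds indistinguishable. For this pair, the position of the methyl on the ring attached to that nitrogen makes no difference that can be read in this assay, although the two groups are joined differently and have the same atoms, ring and counts of hydrogen-bond donors and acceptors. Nothing on hand offers an explanation for this result or shows what lies behind it.

As far as these compounds go, this single step concerns only a methyl on that ring, so it remains open whether a methoxy group, a chlorine atom, an amine or a carboxylic acid there would give a number beyond the scatter from that of compound 3. From the compounds shown here alone, it is also open whether the same exchange of 3-methylphenyl for 2-methylphenyl would give a similarly small step on a compound with a different group at the far end of the amide chain.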